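The source may hold more compounds than are shown below. What is called first, only, known or untested is meant among the compounds shown, and "the series" means these compounds.

Measured compounds in a functional assay on Maver1 cells (Homo sapiens) for inhibition, read by luminescence and CellTiter-Glo, with a stated time of 72 h; a lower number here means a stronger inhibitor, a higher number a weaker inhibitor:
compound 1 `C=CC(=O)Nc1ccc(Cn2nc(-c3ccc(Oc4ccccc4)cc3)cc2C(=O)O)cc1`: > 60000 nM, which is a limit of the assay, not a number
compound 2 `C=CC(=O)Nc1ccc(Cn2nc(-c3ccc(Oc4ccccc4)cc3)cc2CO)cc1`: 7000 nM

Compound 1 stands at the limit of > 60000 nM in this assay, at which 1 of the 2 values shown sits; nothing more than that limit is known of it. Going by the values given here, the one measured step, an at least 8.5-fold lower number from compound 1 to compound 2 (0.93 log units; beyond the scatter), concerns hydroxymethyl in place of carboxy on an aromatic carbon and leaves the carboxy-bearing compound at the limit.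

Compound 3 `O=C(CCl)Nc1cccc(Cn2nc(-c3ccc(Oc4ccccc4)cc3)cc2C(=O)O)c1` keeps the carboxy of compound 1 and differs from it by 3-(((chloromethyl)carbonyl)amino)phenyl in place of 4-((vinylcarbonyl)amino)phenyl on a saturated chain carbon bound to an aromatic nitrogen. Among the compounds with values here, no measured step touches this part of the molecule, so the step from compound 1 to compound 3 has no direct precedent; the one measured step bears on it only in showing that the carboxy-bearing compound 1 sits at the limit.

Compound 3 is therefore expected to stay weak in this assay, with an at least 1.3-fold lower number from compound 1 to compound 3 (0.12 log units; that floor lies within the scatter) expected to lie within the scatter of a compound at the limit. The estimate for compound 3 is 45000 nM, in a range from 12000 nM to 100000 nM.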

Compound 3, half-maximal inhibitory concentration: 4700 nM
Estimate against measurement, compound 3: 9.6-fold (0.98 log units) above, and the stated range ends above it.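

In this assay, the carboxy group does not by itself hold a compound at the weak end, since compound 3 keeps it and reads 4700 nM. Replacing 4-((vinylcarbonyl)amino)phenyl with 3-(((chloromethyl)carbonyl)amino)phenyl on a saturated chain carbon bound to an aromatic nitrogen gives an at least 12-fold lower number from compound 1 to compound 3 (1.10 log units; beyond the scatter), so this part of the molecule, untouched by the earlier step, also moves the read-out. Compound 1 remains a limit, not a number, so the true size of this step stays unknown: the limit of > 60000 nM in this assay, at which 1 of the 3 values shown sits.

The step changes both the acyl group and the 3- or 4-placement on the phenyl, and the compounds shown do not separate the two. Open too, from the compounds shown here alone, is how 3-(acetylamino)phenyl, with a plain methyl in place of chloromethyl, would read with the carboxy kept.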